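From pyridin-3-yl to 2-fluorophenyl on the chain

The source may hold more compounds than are shown below. What is called first, only, known or untested is meant among the compounds shown, and "the series" means these compounds.

In a functional assay on HeLa cells (Homo sapiens) for cytotoxicity, read by WST assay, with a stated time of 48 h (a lower number here means a stronger inhibitor, a higher number a weaker inhibitor), compound 1 `COc1cccc(/C=C/C[C@H]2C[C@@H]([C@@H](O)c3ccccc3)CO[C@@H]2c2ccccc2)c1` gives 10900 nM and compound 2 `COc1ccccc1/C=C/C[C@H]1C[C@@H]([C@@H](O)c2ccccc2)CO[C@@H]1c1ccccc1` gives 14700 nM. In this assay, compound 3 `O[C@@H](c1ccccc1)[C@H]1CO[C@H](c2ccccc2)[C@@H](C/C=C/c2cccnc2)C1` reaches only a limit, > 100000 nM, and so has no number of its own.

Compound 4 `O[C@@H](c1ccccc1)[C@H]1CO[C@H](c2ccccc2)[C@@H](C/C=C/c2ccccc2F)C1` departs from compound 3 in one place, (2-fluorophenyl in place of pyridin-3-yl on a double-bonded chain carbon bound to a double-bonded chain carbon). For the measured compounds named here, the ring that enters is an aromatic ring of carbon only, as in compound 1 and compound 2, although no measured compound carries a 2-fluorophenyl group. Going by the values given here, three measured steps bear on the change. Replacing either methoxyphenyl group with pyridin-3-yl gave an at least 9.1-fold higher number from compound 1 to compound 3 (0.96 log units; beyond the scatter) and an at least 6.8-fold higher number from compound 2 to compound 3 (0.83 log units; beyond the scatter). Moving between the two methoxyphenyl groups gave only a 1.3-fold higher number from compound 1 to compound 2 (0.13 log units; within the scatter). Read in reverse, the two larger steps suggest that leaving pyridin-3-yl should lower the number by a modest step or more. The expected change is an at least 6.6-fold lower number from compound 3 to compound 4 (0.82 log units; beyond the scatter). Compound 4 is expected at about 15000 nM, with an estimated range of 6000 nM to 45000 nM.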

Compound 4, half-maximal inhibitory concentration: 9730 nM
Compound 4: middle estimate off by 1.5-fold (0.19 log units), on the high side, within the range that was stated.
By their numbers in this assay, from the lowest: compounds 4, 1 and 2 (each within the scatter of the next). At a limit, above all of these: compound 3.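

In this assay, for the compounds shown here, 2-fluorophenyl on this chain carbon gives an at least 10-fold lower number from compound 3 to compound 4 (1.01 log units; beyond the scatter), so the number falls into the range of the methoxyphenyl compounds, and three compounds with a carbon-only aromatic ring now stand against the single pyridin-3-yl compound. On these data alone, the size of that step remains open-ended because compound 3 stands at a limit: the limit of > 100000 nM in this assay, at which 1 of the 4 values shown sits. Which group sits on the carbon-only ring makes no difference that can be read here, since fluoro in place of methoxy gives a 1.5-fold lower number from compound 2 to compound 4 (0.18 log units; within the scatter) and the change from 3-methoxyphenyl gives a 1.1-fold lower number from compound 1 to compound 4 (0.05 log units; within the scatter).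

As far as these compounds go, whether an unsubstituted phenyl, an amine or carboxylic acid on the ring, or a longer chain would move the number away from those of compound 1, compound 2 and compound 4 remains open. From the compounds shown here alone, all four values come from a single cell line, so whether the gap to compound 3 holds in other cells is also open.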